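Replacing the Thiazole Arm: Expected Cytotoxicity of Compound 4

This account rests on a few compounds, and the source may have more. Where it says the series, first, only, none or still open, it means among the compounds named here.

Three macrocyclic compounds share one core and differ on a single aromatic carbon. Compound 1 `COc1ccc2c(OCC[C@@H]3NC(=O)N(C)CCCC/C=C\[C@@H]4C[C@@]4(C(=O)NS(=O)(=O)C4(C)CC4)NC3=O)cc(-c3nc(C(C)C)cs3)nc2c1` carries a hydrogen there, and in an ADME assay on cells (Homo sapiens) for activation (on this read-out lower numbers stand for higher toxicity in this test and higher numbers for lower toxicity in this test), compound 1 gives 6500 nM. Compound 2 `COc1ccc2c(OCC[C@@H]3NC(=O)N(C)CCCC/C=C\[C@@H]4C[C@@]4(C(=O)NS(=O)(=O)C4(C)CC4)NC3=O)cc(-c3nc(C(C)C)cs3)nc2c1Cl` carries a chloro group; in this assay compound 2 gives 37400 nM. Compound 3 `COc1ccc2c(OCC[C@@H]3NC(=O)N(C)CCCC/C=C\[C@@H]4C[C@@]4(C(=O)NS(=O)(=O)C4(C)CC4)NC3=O)cc(-c3nc(C(C)C)cs3)nc2c1C` carries a methyl group, and in this assay compound 3 gives 31900 nM, the second highest of the three numbers, with compound 2 close by, a 1.2-fold lower number from compound 2 to compound 3 (0.07 log units; within the scatter). Both substitutions raised the number from compound 1: a 5.8-fold higher number from compound 1 to compound 2 (0.76 log units; beyond the scatter) and a 4.9-fold higher number from compound 1 to compound 3 (0.69 log units; beyond the scatter).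

Compound 4 `CCn1cc(-c2cc(OCC[C@@H]3NC(=O)N(C)CCCC/C=C\[C@@H]4C[C@@]4(C(=O)NS(=O)(=O)C4(C)CC4)NC3=O)c3ccc(OC)c(C)c3n2)cn1` keeps the methyl of compound 3 but changes a different part: 1-ethyl-1H-pyrazol-4-yl in place of 4-isopropyl-1,3-thiazol-2-yl on an aromatic carbon. Among the measured compounds shown here, none of the measured steps touches this position or this kind of exchange, so they give no guide to its size or direction. With the rest of the molecule unchanged, compound 4 is expected to stay near compound 3, a 1.1-fold lower number from compound 3 to compound 4 (0.03 log units; within the scatter), with no step beyond the scatter expected. The estimate for compound 4 in this assay is 30000 nM, within a range from 10000 nM to 90000 nM.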

Compound 4, half-maximal cytotoxic concentration: 36700 nM
Beside the measured number, compound 4's estimate is 1.2-fold (0.09 log units) below it; the measured number falls inside the stated range.
By their numbers in this assay, from the lowest: compound 1; then compounds 3, 4 and 2 (each within the scatter of the next).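

Placing 1-ethyl-1H-pyrazol-4-yl in place of 4-isopropyl-1,3-thiazol-2-yl, next to the ring nitrogen, gives the first reading at this position, and in this assay the two compounds cannot be told apart (a 1.2-fold higher number from compound 3 to compound 4 (0.06 log units; within the scatter)). Within this pair, then, one five-membered aromatic ring with 2 hetero atoms can stand in for another, even though the sulfur goes, a second nitrogen enters and the alkyl group differs, with no step beyond the usual scatter. Nothing shown here gives a reason for this outcome.

These compounds leave open whether the same holds for a ring bearing an amine or a carboxylic acid, or for a longer chain in place of the ethyl group. They also leave open whether this exchange would read the same with the chloro group of compound 2 in place of the methyl group.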